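Aryl swap on the oxazole series, solubility outlook

The source may report more compounds than this note shows. Statements on the series, on what has been measured and on what is new or still open speak of the compounds shown alone.

Three compounds of this series have a value in a physicochemical assay for solubility, in phosphate buffer, measured as kinetic solubility, at pH 7.4; on this read-out higher numbers stand for higher solubility and lower numbers for lower solubility. Compound 1 `Cc1ccccc1-c1nc(CN2CCC(C(=O)NCCCN3CCCCC3)CC2)c(C)o1` gives > 65 ug/mL, a limit of the assay and not a number. Compound 3 `CCCN(CCC)CCNC(=O)C1CCN(Cc2nc(-c3ccccc3C)oc2C)CC1` gives > 65 ug/mL, again a limit. Compound 2 `Cc1oc(-c2c(Cl)cccc2Cl)nc1CN1CCC(C(=O)NCCCN2C[C@H](C)C[C@H](C)C2)CC1` gives > 77 ug/mL, also a limit, so compound 2 sits at the upper boundary of what the assay reports, the same boundary shown in the limit of > 77 ug/mL in this assay, at which 1 of the 3 values shown sits, while the two other values sit at the limit of > 65 ug/mL in this assay, at which 2 of the 3 values shown sit. Among the compounds with values here, the one step between compounds differing in a single place, a step that the two limits leave unreadable from compound 1 to compound 3, is unreadable, since both ends are limits.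

Compound 4 `COc1cccc(C)c1-c1nc(CN2CCC(C(=O)NCCCN3C[C@H](C)C[C@H](C)C3)CC2)c(C)o1` differs from compound 2 by 2-methoxy-6-methylphenyl in place of 2,6-dichlorophenyl on an aromatic carbon. Within the data shown here, no measured step bears on this change; compound 1, which carries a 2-methylphenyl group on the same position of the shared core, is itself at a limit, so nothing suggests a drop. The step is expected to stay within the scatter, a step that the limit leaves unreadable from compound 2 to compound 4, with compound 4 most likely again reported as a limit. Compound 4 is estimated at 90 ug/mL, within 40 ug/mL to 200 ug/mL.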

Compound 4, solubility: > 73 ug/mL
Compound 4 was reported as a limit (the forecaster's own chance of this, stated with the estimate: 80%); the middle value is on the limit's open side.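

In this assay compound 4 gives > 73 ug/mL, a limit and not a number, and compound 2 also stands at a limit, so no step can be read between these two compounds. The compounds shown leave open whether 2-methoxy-6-methylphenyl in place of 2,6-dichlorophenyl shifts the read-out at all, since all four values are limits.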